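Fluoro for methyl on the benzyl group of compound 2

The compounds below may be only part of what the source reports. "The series", "measured", "known", "first", "only" and "open" are said of these compounds alone.

Compound 1, `COc1cccc(Sc2sc(C(C)=O)nc2[N+](=O)[O-])c1`: > 50000 nM
Compound 2, `Cc1ccc(CNC(=O)c2nc([N+](=O)[O-])c(Sc3c(Cl)cncc3Cl)s2)cc1`: 3650 nM

In an assay on isolated protein for inhibition of ubiquitin carboxyl-terminal hydrolase 7 (Homo sapiens), read by fluorescence, with stated times of 30 min and 3 h (a higher number here means a weaker inhibitor, a lower number a stronger inhibitor), compound 1 gives only a limit, > 50000 nM, and no number. In this assay, going by the values given here, compound 2 gives 3650 nM, the only numeric value measured here. Compound 3, `O=C(NCc1ccc(F)cc1)c1nc([N+](=O)[O-])c(Sc2c(Cl)cncc2Cl)s1`, differs from compound 2 by fluoro in place of methyl on an aromatic carbon. No measured step of this kind exists among these compounds, so the step of a 1.1-fold higher number from compound 2 to compound 3 (0.04 log units; within the scatter) is expected to be small, within the scatter of repeated measurements, with no clear direction. Compound 3 is therefore estimated at 4000 nM in this assay, in the range 1500 nM to 12000 nM.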

Compound 3, half-maximal inhibitory concentration: 2650 nM
Compound 3: middle estimate off by 1.5-fold (0.18 log units), on the high side, and the stated range covers the measured number.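

Fluoro in place of methyl on this aromatic carbon, para to a large group, gives a 1.4-fold lower number from compound 2 to compound 3 (0.14 log units; within the scatter) in this assay. Going by these compounds alone, this is the first measured step at this position, and it shows that 4-methylbenzyl and 4-fluorobenzyl cannot be told apart here. Nothing shown bears on a cause for this result.

Only these two small groups have been compared at this position. From the compounds shown here alone, whether an amine, a carboxylic acid or a longer chain there would move the number beyond the scatter remains open.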